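Biphenyl to fluoropyridinyloxy on the benzyl arm of an isatin

This account rests on a few compounds, and the source may have more. Where it says the series, first, only, none or still open, it means among the compounds named here.

Compound 1 `O=C1C(=O)N(Cc2ccc(-c3ccccc3)cc2)c2ccc(OC(F)(F)F)cc21`: 1600 nM
Compound 2 `O=C1C(=O)N(Cc2ccc(-c3ccccc3)cn2)c2ccc(OC(F)(F)F)cc21`: 3100 nM
Compound 3 `O=C1C(=O)N(Cc2ccc(-c3cccnc3)nc2)c2ccc(OC(F)(F)F)cc21`: 4000 nM

Of the compounds shown here, three have been measured in a functional assay on CHO cells for positive allosteric modulation of muscarinic acetylcholine receptor M5 (Homo sapiens), read by FLIPR and calcium flux, with a stated time of 1 h; a higher number here means that more compound is needed for the effect, a lower number that less compound is needed. Compound 1 gives 1600 nM, the lowest of the three numbers, and compound 2 gives 3100 nM, which lies within the scatter of compound 1, so the two cannot be placed in order. Within the data shown here, compound 3 gives 4000 nM, a number that stands beyond the scatter above compound 1; of the three, only this pair shows a difference that can be read as real.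

Compound 4 `O=C1C(=O)N(Cc2ccc(Oc3cccc(F)n3)cc2)c2ccc(OC(F)(F)F)cc21` has not been measured. It differs from compound 1 in one place: (6-fluoropyridin-2-yl)oxy in place of phenyl on an aromatic carbon. Among the measured compounds shown here, no measured pair shows this kind of change, so the expectation for compound 4 rests only on compound 1 and on the size of the change itself.

The account expects a modest step upward in this assay from compound 1 to compound 4, that is, somewhat more compound needed, with a step of about a 1.6-fold higher number from compound 1 to compound 4 (0.19 log units; within the scatter), which may itself fall within the scatter. For compound 4 the estimated value in this assay is 2500 nM, with a range from 900 nM to 7000 nM.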

Compound 4, half-maximal effective concentration: 1500 nM
Compound 4: middle estimate off by 1.7-fold (0.22 log units), on the high side; low and high end bracket the measured number.
By their numbers in this assay, from the lowest: compounds 4, 1, 2 and 3 (each within the scatter of the next, the first and the last beyond it).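

In this assay, putting (6-fluoropyridin-2-yl)oxy in place of phenyl on an aromatic carbon, para to a large group, gives a 1.1-fold lower number from compound 1 to compound 4 (0.03 log units; within the scatter), so the two compounds cannot be placed in order. This is the first step shown that changes a single place, and it shows that this position can take a larger group, with more heavy atoms, a hetero atom in the ring and hydrogen-bond acceptors, without the number moving beyond the scatter. No measurement at hand gives a reason for this result.

The oxygen link and the fluoropyridine ring enter together, so the compounds shown leave open what each contributes on its own, a question that a plain phenoxy group or an unsubstituted pyridinyloxy group in the same place could address. Also open, on these data alone, is how much further this position can be varied: whether an amine, a carboxylic acid or a longer chain here would give a number that stands clearly apart from that of compound 1.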